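From butoxy to methylsulfanyl on the shared core

The source may report more compounds than this note shows. Statements on the series, on what has been measured and on what is new or still open speak of the compounds shown alone.

Within the data shown here, only two compounds have values so far. In a functional assay on KB cells (Homo sapiens) for inhibition (on this read-out higher numbers stand for weaker inhibition and lower numbers for stronger inhibition), compound 1 (`CC(=O)OC1C(CI)OC(n2c(Cl)nc3cc(Cl)c(Cl)cc32)C1OC(C)=O`) gives 60000 nM and compound 2 (`CCCCOC[C@H]1OC(n2c(Cl)nc3cc(Cl)c(Cl)cc32)[C@H](O)[C@@H]1O`) gives 60000 nM as well, so compound 2 stands level with compound 1, within the scatter. These two differ in more than one place, so no measured single change is available to size the next step.

Compound 3 (`CSC[C@H]1OC(n2c(Cl)nc3cc(Cl)c(Cl)cc32)[C@H](O)[C@@H]1O`) is still unmeasured. It carries methylsulfanyl in place of butoxy on a saturated chain carbon bound to a saturated ring carbon. The data show nothing yet about how this replacement acts on its own. The only anchor is the shared level of compound 1 at 60000 nM and compound 2 at 60000 nM, and from that anchor no step beyond the scatter is expected in this assay, in either direction. The estimated step (a 1.2-fold lower number from compound 2 to compound 3 (0.08 log units; within the scatter)) is therefore a small one. In this assay the estimated value for compound 3 is 50000 nM (expected range 20000 nM to 120000 nM).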

Compound 3, half-maximal inhibitory concentration: > 100000 nM
Compound 3: a limit, no number; the forecaster's own chance of this, stated with the estimate: 25%; middle value at least 2.0-fold (0.30 log units) from the limit.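

In this assay compound 3 gives > 100000 nM, which is a limit of the assay and not a number. Methylsulfanyl in place of butoxy on a saturated chain carbon bound to a saturated ring carbon is the first change in this series that can be read in one place, and it gives an at least 1.6-fold higher number from compound 2 to compound 3 (0.22 log units; that floor lies within the scatter), so this position now has a step with a floor, though that floor does not separate the two compounds beyond the scatter. The step has no upper end, and its full size cannot be read, since the result for compound 3 stands at a limit: the limit of > 100000 nM in this assay, at which 1 of the 3 values shown sits.

The compounds shown leave open whether compound 2 and compound 3 truly differ beyond the scatter, and whether the sulfur or the shorter chain would matter on its own, as the two enter together in this single change. An ethoxy group or an amine on the same saturated chain carbon, read against compound 2, would separate chain length from the atom that carries the chain.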